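Swapping an ethynyl-linked thiophene for a directly attached chlorophenyl

This account rests on a few compounds, and the source may have more. Where it says the series, first, only, none or still open, it means among the compounds named here.

Of the compounds shown here, three of one shared core have been tested in a functional assay on CAPAN-1 cells (Homo sapiens) for antiproliferative activity, with a stated time of 72 h; on this read-out higher numbers stand for weaker inhibition and lower numbers for stronger inhibition. Compound 1 `Nc1ncnn2c([C@@H]3O[C@H](CO)[C@@H](O)[C@H]3O)cc(C#Cc3ccc(F)cc3)c12` gives 55400 nM, compound 2 `Nc1ncnn2c([C@@H]3O[C@H](CO)[C@@H](O)[C@H]3O)cc(C#Cc3cccs3)c12` gives 32000 nM, and compound 3 `COc1ccc(-c2cc([C@@H]3O[C@H](CO)[C@@H](O)[C@H]3O)n3ncnc(N)c23)cc1` gives 43900 nM. Compound 2 holds the lowest of the three numbers, yet both gaps to it are within the scatter: a 1.7-fold lower number from compound 1 to compound 2 (0.24 log units; within the scatter) and a 1.4-fold higher number from compound 2 to compound 3 (0.14 log units; within the scatter). Among the compounds with values here, the one measured step that swaps the triple-bonded arm for a directly attached ring, a 1.3-fold lower number from compound 1 to compound 3 (0.10 log units; within the scatter), is also within the scatter.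

Compound 4 `Nc1ncnn2c([C@@H]3O[C@H](CO)[C@@H](O)[C@H]3O)cc(-c3ccccc3Cl)c12` arises from compound 2 by a change of the same kind: 2-chlorophenyl in place of 2-(thiophen-2-yl)ethynyl on an aromatic carbon. The step from compound 2 to compound 3 is the closest guide, and it showed nothing beyond the scatter; the step from compound 1 to compound 3 points the same way. Compound 4 is therefore expected to land near the other three, with an estimated 1.3-fold higher number from compound 2 to compound 4 (0.10 log units; within the scatter). The estimate for compound 4 in this assay is 40000 nM, with a range from 15000 nM to 110000 nM.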

Compound 4, half-maximal inhibitory concentration: 54900 nM
Compound 4: the middle estimate sits 1.4-fold (0.14 log units) below what was measured, within the range that was stated.
By their numbers in this assay, from the lowest: compounds 2, 3, 4 and 1 (each within the scatter of the next).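

At this position on the shared core, this assay does not separate 2-chlorophenyl from 2-(thiophen-2-yl)ethynyl (a 1.7-fold higher number from compound 2 to compound 4 (0.23 log units; within the scatter)), from 4-methoxyphenyl (a 1.3-fold higher number from compound 3 to compound 4 (0.10 log units; within the scatter)), or from 2-(4-fluorophenyl)ethynyl (a 1.0-fold lower number from compound 1 to compound 4 (0.00 log units; within the scatter)). A second directly attached ring, carrying chlorine instead of methoxy, therefore joins the two triple-bonded arms, and all four compounds stay within the scatter of one another. Nothing measured here explains why these numbers stay so close.

Every group shown at this aromatic carbon contains an aromatic ring, so the effect of a small amine, a carboxylic acid or a longer saturated chain remains open. As far as these compounds go, it is also open whether any group at this position can move the number in this assay beyond the scatter.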